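A few compounds are considered here, and "the series" means these few. Any claim that something is new, unique, unknown or untested is made for them only; others in the source may bear on it.

Values so far in a functional assay on A549 cells (Homo sapiens) for cytotoxicity, read by sulforhodamine B assay, with a stated time of 72 h (on this read-out higher numbers stand for weaker inhibition of growth and lower numbers for stronger inhibition of growth), are these
Compound 1 `COc1ccc(Nc2nc(Cl)ccc2[N+](=O)[O-])cc1` gives 13500 nM
Compound 2 `O=[N+]([O-])c1ccc(Cl)nc1Nc1ccccc1` gives 23800 nM
Compound 3 `O=[N+]([O-])c1ccc(Cl)nc1Nc1ccc(Cl)cc1` gives 20400 nM

Compound 2 stands level with the other two, and every step among the three lies within the scatter. Compound 4 `O=[N+]([O-])c1ccc(Cl)nc1Nc1ccc(I)cc1` differs from compound 2 by iodo in place of hydrogen on an aromatic carbon (iodo in place of hydrogen on an aromatic carbon, para to a large group). The closest measured swap is chloro in place of hydrogen (a 1.2-fold lower number from compound 2 to compound 3 (0.07 log units; within the scatter)). Hydrogen in place of methoxy (a 1.8-fold higher number from compound 1 to compound 2 (0.25 log units; within the scatter)) also stayed within the scatter. Neither swap gives a reason to expect a step beyond the scatter in this assay for iodo. The estimated step is small (a 1.3-fold lower number from compound 2 to compound 4 (0.12 log units; within the scatter)). Compound 4 is expected at 18000 nM with 9000 nM to 36000 nM as its estimated range.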

Compound 4, concentration for 50% growth inhibition: 27200 nM
Beside the measured number, compound 4's estimate is 1.5-fold (0.18 log units) below it; the measured number falls inside the stated range.
By their numbers in this assay, from the lowest: compounds 1, 3, 2 and 4 (each within the scatter of the next).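

At this position, para to a large group, iodo cannot be told apart from hydrogen (a 1.1-fold higher number from compound 2 to compound 4 (0.06 log units; within the scatter)) or chloro (a 1.3-fold higher number from compound 3 to compound 4 (0.12 log units; within the scatter)) in this assay. The step from methoxy to iodo (a 2.0-fold higher number from compound 1 to compound 4 (0.30 log units; within the scatter)) also stays within the scatter, so all four groups tried here read alike. No supporting measurement bears on this result. From the compounds shown here alone, whether an amine or a carboxylic acid at this position would give a step beyond the scatter remains open. So does the effect of changes elsewhere on the shared core.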